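A few compounds are considered here, and "the series" means these few. Any claim that something is new, unique, unknown or untested is made for them only; others in the source may bear on it.

Compound 2, whose structure is `C=C(C)C(=O)Nc1cccc(-c2nc3ccccc3s2)c1`, is the measured starting point of this step. In an ADME assay on Raji cells (Homo sapiens) for inhibition, with a stated time of 72 h (on this read-out lower numbers stand for an effect already at smaller amounts and higher numbers for an effect only at larger amounts of compound), compound 2 gives only a limit, namely > 25000 nM. For the measured compounds named here, its one neighbour among the measured compounds is compound 1, with the structure `C=CC(=O)Nc1cccc(-c2nc3ccccc3s2)c1`. In this assay compound 1 likewise gives only a limit, > 25000 nM. Going by the values given here, the single measured step, a step that the two limits leave unreadable from compound 1 to compound 2, therefore cannot be read, and the two values shown form the whole of the evidence, summed up as the limit of > 25000 nM in this assay, at which 2 of the 2 values shown sit. The unmeasured compound 3 has the structure `CC(C)(CCl)C(=O)Nc1cccc(-c2nc3ccccc3s2)c1`. The change from compound 2 is 1-(chloromethyl)-1-methylethyl in place of 1-methylethenyl on a carbonyl carbon. Among the compounds with values here, the only measured step bears on this change in no readable way, since both its ends sit at the limit, so there is no measured size on which to build and the expected direction of the step cannot be taken from the data. The step from compound 2 to compound 3 is expected to be about a step that the limit leaves unreadable from compound 2 to compound 3. For compound 3 the estimate is 40000 nM, with a range from 12000 nM to 120000 nM.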

Compound 3, half-maximal effective concentration: > 25000 nM
Compound 3 was reported as a limit (the forecaster's own chance of this, stated with the estimate: 70%); the middle value does not contradict the limit.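

The steps joining compound 3 to compound 1 and to compound 2 cannot be read in this assay, as all three compounds stand at one limit: the limit of > 25000 nM in this assay, at which 3 of the 3 values shown sit.

The compounds shown leave open whether any of these changes on the carbonyl carbon alters the read-out, and how the true values of the three compounds relate to one another.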